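Demethylation of a Trimethoxy Hydrazone: Cytotoxicity Outlook

A few compounds are considered here, and "the series" means these few. Any claim that something is new, unique, unknown or untested is made for them only; others in the source may bear on it.

Within the data shown here, compound 1 `COc1cc(/C=N/NC(=O)COc2cccc3ccccc23)cc(OC)c1OC` is one of two compounds measured so far in an ADME assay on MT4 cells (Homo sapiens) for cytotoxicity, read by MTT assay, with a stated time of 4 days (on this read-out higher numbers stand for lower toxicity in this test and lower numbers for higher toxicity in this test), and it stands at the lower of the two numbers: in this assay compound 1 gives 13.4 ug/mL. Among the measured compounds shown here, its only neighbour is compound 2 `COc1ccc(/C=N/NC(=O)COc2cccc3ccccc23)cc1OC`, which in this assay gives 14.7 ug/mL. The step between them, a 1.1-fold higher number from compound 1 to compound 2 (0.04 log units; within the scatter), comes from hydrogen in place of methoxy on an aromatic carbon, and it lies within the scatter of the measurement.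

Compound 3 `COc1cc(/C=N/NC(=O)COc2cccc3ccccc23)cc(OC)c1O` is not yet measured. It differs from compound 1 by hydrogen in place of methyl on an oxygen on an aromatic ring, that is, methoxy becomes hydroxy on the shared core. For the measured compounds named here, no measured step shows this kind of change; the only step available, from compound 1 to compound 2, alters a different part of the same ring and stays within the scatter. On that basis compound 3 is expected to remain close to compound 1 in this assay, with no step beyond the scatter, so that a 1.0-fold lower number from compound 1 to compound 3 (0.01 log units; within the scatter) is the expected outcome. The estimate for compound 3 in this assay is therefore 13 ug/mL, with a range from 6 ug/mL to 28 ug/mL.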

Compound 3, half-maximal cytotoxic concentration: 16.3 ug/mL
Estimate against measurement, compound 3: 1.3-fold (0.10 log units) below; the measured number falls inside the stated range.
By their numbers in this assay, from the lowest: compounds 1, 2 and 3 (each within the scatter of the next).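

Among these compounds, the methoxy to hydroxy swap, hydrogen in place of methyl on an oxygen on an aromatic ring, had not been tested by the earlier compounds, and in this assay it gives a 1.2-fold higher number from compound 1 to compound 3 (0.09 log units; within the scatter). The earlier step on the same ring, a 1.1-fold higher number from compound 1 to compound 2 (0.04 log units; within the scatter), removed a methoxy group outright, so two different edits of compound 1 on this ring have now been read, and neither gives a step beyond the scatter. No measured information is available to explain this result.

The compounds shown leave open whether any replacement on this oxygen can produce a step beyond the scatter, for instance a longer chain such as ethoxy, or whether an amine in place of the hydroxy of compound 3 would do so. From the compounds shown here alone, they also say nothing about the rest of the shared core, so it remains unknown whether the read-out responds to edits elsewhere in the molecule, such as on the hydrazone linker or on the far ring.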